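Allyl in Place of Propargyl on the Amide Nitrogen

The source may hold more compounds than are shown below. What is called first, only, known or untested is meant among the compounds shown, and "the series" means these compounds.

Measured compounds:
Compound 1, `C=CCNC(=O)/C(C)=C(\C)c1cc(OC)c(OC)c(OC)c1`: 280 mg/kg
Compound 2, `C#CCNC(=O)/C(C)=C(\C)c1cc(OC)c(OC)c(OC)c1`: 300 mg/kg
Compound 3, `C#CCNC(=O)/C(C)=C(\C)c1ccc(C)cc1`: 200 mg/kg

All three compounds were tested in a toxicity assay on the whole organism (strain Icem-CET (SPF Caw)) for cytotoxicity, with Mus musculus as the target; on this read-out higher numbers stand for an effect only at larger amounts of compound and lower numbers for an effect already at smaller amounts. Compound 1 gives 280 mg/kg, compound 2 gives 300 mg/kg, and compound 3 gives 200 mg/kg. The three numbers lie close together, and none of the gaps between them exceeds the usual scatter, so no order among the three can be claimed.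

Compound 1 and compound 2 share one core and differ in a single place: vinyl in place of ethynyl on a saturated chain carbon bound to an amide-type nitrogen. This change made a step of a 1.1-fold lower number from compound 2 to compound 1 (0.03 log units; within the scatter) in this assay, which is within the scatter.

The unmeasured compound 4, `C=CCNC(=O)/C(C)=C(\C)c1ccc(C)cc1`, is built from compound 3 by the same change: vinyl in place of ethynyl on a saturated chain carbon bound to an amide-type nitrogen. Among the compounds shown, this change occurs two times in all, once measured and once not. The cores of compound 3 and compound 2 differ as well, but that difference is not broken down here.

Among the measured compounds shown here, since the one measured instance of this change, the step of a 1.1-fold lower number from compound 2 to compound 1 (0.03 log units; within the scatter), stayed within the scatter, a step of similar size is expected from compound 3 to compound 4, that is a 1.1-fold lower number from compound 3 to compound 4 (0.02 log units; within the scatter). The expectation rests on a single pair, so the range is kept wide. Compound 4 is therefore estimated at 190 mg/kg, with a likely span from 110 mg/kg to 330 mg/kg.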

Compound 4, dose for half-maximal effect: 170 mg/kg
For compound 4 the middle estimate is 1.1-fold (0.05 log units) above the measured one; measured number inside the range.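

In this assay, replacing propargyl with allyl on the core of compound 3 gives a 1.2-fold lower number from compound 3 to compound 4 (0.07 log units; within the scatter). Set beside the earlier step on the other core, the change behaves alike on both: the same change on two cores in this assay, a 1.1-fold lower number (0.03 log units; within the scatter) from compound 2 to compound 1 and a 1.2-fold lower number (0.07 log units; within the scatter) from compound 3 to compound 4, 1.1-fold (0.04 log units) apart, within the scatter of two such steps. In these two pairs, then, swapping the triple bond of propargyl for the double bond of allyl moved the number by no more than repeated measurements usually scatter, and the two steps cannot be told apart, but this is a finding about two cores only: it does not show that the change would stay this small on any other core, and steps this small cannot reveal a real trend in either direction.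

The compounds shown carry only propargyl or allyl on the amide nitrogen, so it remains open whether a saturated propyl group, a longer chain such as butyl, or a chain ending in an amine would give a number clearly apart from these. Going by these compounds, it also remains open whether the swap from propargyl to allyl stays this small on a core bearing a carboxylic acid.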